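Trimming the Carboxymethyl Arm: Expected Tolerability of Compound 3

This account rests on a few compounds, and the source may have more. Where it says the series, first, only, none or still open, it means among the compounds named here.

Compound 1 `CCC(=O)Nc1ccc(-c2nc3cc(C(F)(F)F)ccc3n2C2CCCCC2)cc1`: 17000 nM
Compound 2 `O=C(O)CCC(=O)Nc1ccc(-c2nc3cc(C(F)(F)F)ccc3[nH]2)cc1`: > 100000 nM

In an ADME assay on MT4 cells (Homo sapiens) for cytotoxicity, read by MTT assay, with a stated time of 96 h (a higher number here means that more compound is tolerated, a lower number that less compound is tolerated), compound 1 gives 17000 nM. Compound 2 is reported only as a limit of the assay, > 100000 nM, which is the limit of > 100000 nM in this assay, at which 1 of the 2 values shown sits. Compound 3 `CC(=O)Nc1ccc(-c2nc3cc(C(F)(F)F)ccc3[nH]2)cc1` differs from compound 2 by hydrogen in place of carboxymethyl on a saturated chain carbon bound to a carbonyl carbon. Among the compounds with values here, no measured pair shows this change, so its effect is unknown; the author expects a modest downward step, an at least 2.0-fold lower number from compound 2 to compound 3 (0.30 log units; that floor lies within the scatter), for compound 3. Compound 3 is therefore estimated at 50000 nM, within 15000 nM to 150000 nM.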

Compound 3, half-maximal cytotoxic concentration: 19000 nM
Estimate against measurement, compound 3: 2.6-fold (0.42 log units) above, within the range that was stated.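

In this assay, hydrogen in place of carboxymethyl on a saturated chain carbon bound to a carbonyl carbon gives an at least 5.2-fold lower number from compound 2 to compound 3 (0.72 log units; beyond the scatter). Within the data shown here, this is the first evidence that a change at this position can shift the read-out beyond the scatter. Compound 2 stands only at a limit, so the step has a lower bound and no upper one: the limit of > 100000 nM in this assay, at which 1 of the 3 values shown sits.

The compounds shown leave open whether the carboxylic acid itself accounts for this step. They also leave open how an amine or a longer chain ending in a carboxylic acid would fare at this place.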